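Benzofuranyl to thiophenyl on the oxo core: compound 4

The source may hold more compounds than are shown below. What is called first, only, known or untested is meant among the compounds shown, and "the series" means these compounds.

Working notes on the series. Compound 1 `Nc1nc(N)c2c(-c3ccsc3)cn([C@@H]3O[C@H](CO)[C@@H](O)[C@H]3O)c2n1` reaches only the limit of > 20000 nM in a functional assay on K562 cells (Homo sapiens), read by MTT assay, with a stated time of 72 h; a lower number here means a stronger inhibitor, a higher number a weaker inhibitor. Compound 2 `COc1nc(N)nc2c1c(-c1cc3ccccc3o1)cn2[C@@H]1O[C@H](CO)[C@@H](O)[C@H]1O` gives 14600 nM in this assay. Compound 3 `O=c1[nH]cnc2c1c(-c1cc3ccccc3o1)cn2[C@@H]1O[C@H](CO)[C@@H](O)[C@H]1O` likewise reaches only the limit of > 20000 nM in this assay. Compound 3 thus stands at the limit of > 20000 nM in this assay, at which 2 of the 3 values shown sit, so no number for it is known, only that it lies beyond what the assay resolves.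

Compound 4 `O=c1[nH]cnc2c1c(-c1ccsc1)cn2[C@@H]1O[C@H](CO)[C@@H](O)[C@H]1O` has not yet been measured in this assay. It differs from compound 3 in one place: thiophen-3-yl in place of 1-benzofuran-2-yl on an aromatic carbon. Among the compounds with values here, no measured pair isolates this exchange, so its size and direction cannot be read from the data. What can be said is that compound 1, which also carries the thiophen-3-yl group, reaches only the limit of > 20000 nM in this assay.

Compound 4 is therefore expected to remain weak, with an estimated 28000 nM between 9000 nM and 90000 nM, and a measured value would most likely again be reported as a limit. The step that the limit leaves unreadable from compound 3 to compound 4 that this estimate implies is expected to fall within the scatter.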

Compound 4, half-maximal inhibitory concentration: > 20000 nM
Compound 4 ended at the assay's limit; the forecaster's own chance of this, stated with the estimate: 75%; the middle value lies beyond the limit too.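

Compound 3 and compound 4 both stand only at a limit in this assay, so no step can be read for thiophen-3-yl in place of 1-benzofuran-2-yl. The compounds shown leave open how far either compound lies beyond that limit, and whether this exchange shifts activity at all.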